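Benzimidazolylmethylthio pyrimidines: three limits, one untested benzylamine

A few compounds are considered here, and "the series" means these few. Any claim that something is new, unique, unknown or untested is made for them only; others in the source may bear on it.

Compound 1, `Cc1cc(NC(C)C)nc(SCc2nc3ccccc3[nH]2)n1`, gives only the assay limit, > 100000 nM, in a functional assay on MCF7 cells (Homo sapiens) for cytotoxicity, read by MTT assay, with a stated time of 72 h; a lower number here means a stronger inhibitor, a higher number a weaker inhibitor.
Compound 2, `Cc1cc(NCCO)nc(SCc2nc3ccccc3[nH]2)n1`, gives only the limit > 100000 nM in this assay.
Compound 3, `Cc1cc(NNC(N)=S)nc(SCc2nc3ccccc3[nH]2)n1`, gives only the limit > 100000 nM in this assay.

Compound 3 therefore stands nowhere in particular on these numbers: it sits at a limit, and the two other values shown sit at the same limit. The three single-site steps between these compounds, a step that the two limits leave unreadable from compound 1 to compound 2, a step that the two limits leave unreadable from compound 1 to compound 3 and a step that the two limits leave unreadable from compound 2 to compound 3, cannot be sized, because every value rests at the limit of > 100000 nM in this assay, at which 3 of the 3 values shown sit.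

Compound 4, `Cc1cc(N(C)Cc2ccccc2)nc(SCc2nc3ccccc3[nH]2)n1`, differs from compound 3 in one place: a group of 9 heavy atoms (8 carbon, 1 nitrogen; one six-membered aromatic ring of carbon only) in place of a group of 5 heavy atoms (1 carbon, 3 nitrogen, 1 sulfur; no ring), on an aromatic carbon. None of the measured steps touches the benzyl(methyl)amino group, and none carries a readable size, so the shown data give no direction for this change; they only show that three different groups on the same nitrogen all left the compounds at the limit in this assay.

Compound 4 is therefore expected to remain near that limit, with an estimate of 150000 nM, in a range from 40000 nM to 600000 nM. The expected step from compound 3 is a step that the limit leaves unreadable from compound 3 to compound 4, which is to say no step beyond the scatter is anticipated.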

Compound 4, half-maximal inhibitory concentration: > 100000 nM
Compound 4: no number, only a limit; the forecaster's own chance of this, stated with the estimate: 70%; the middle value lies beyond the limit too.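

In this assay compound 4 gives > 100000 nM as a limit and not a number. Its steps from compound 1, compound 2 and compound 3 therefore cannot be read: the limit of > 100000 nM in this assay, at which 4 of the 4 values shown sit. The compounds shown leave open which change to the shared core, if any, would give a number in this assay rather than a limit.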